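Pyridin-2-yl in Place of Methoxyphenyl on the Cyclopropane

The source may hold more compounds than are shown below. What is called first, only, known or untested is meant among the compounds shown, and "the series" means these compounds.

Compound 3 `CC[C@H](C)[C@H](N)CN(C(=O)[C@@H]1C[C@H]1c1ccc(OC)cc1)c1ccc(-c2ccccc2)cc1` is one of three compounds examined in a functional assay for agonist activity at G protein-coupled receptor 88 (Homo sapiens), read by HTRF and cAMP accumulation; on this read-out lower numbers stand for an effect already at smaller amounts and higher numbers for an effect only at larger amounts of compound. In this assay compound 3 gives > 25000 nM, which is a limit of the assay and not a number, standing at the limit of > 25000 nM in this assay, at which 1 of the 3 values shown sits. Compound 1 `CC[C@@H](C)[C@H](N)CN(C(=O)[C@@H]1C[C@H]1c1ccccc1)c1ccc(-c2ccccc2)cc1` gives 1.4 nM in this assay, and compound 2 `CC(C)(C)[C@H](N)CN(C(=O)[C@@H]1C[C@H]1c1ccccc1)c1ccc(-c2ccccc2)cc1` gives 11 nM; the step of a 7.9-fold higher number from compound 1 to compound 2 (0.90 log units; beyond the scatter) concerns the saturated chain carbon bound to the amine nitrogen, not the group on the three-membered ring. Compound 4 `CC[C@H](C)[C@H](N)CN(C(=O)[C@@H]1C[C@H]1c1ccccn1)c1ccc(-c2ccccc2)cc1` differs from compound 3 in one place: pyridin-2-yl in place of 4-methoxyphenyl on a saturated ring carbon. Going by the values given here, no measured step alters this group on the saturated ring carbon, so the measured steps offer no direct guide, and the only hint is that compounds 1 and 2 lack the 4-methoxyphenyl group. The expected step of an at least 3.1-fold lower number from compound 3 to compound 4 (0.49 log units; beyond the scatter) is therefore highly uncertain. Compound 4 is estimated at 8000 nM, within a wide range from 400 nM to 25000 nM, and a further limit remains quite possible.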

Compound 4, half-maximal effective concentration: 130 nM
Estimate against measurement, compound 4: 62-fold (1.79 log units) above; measured number outside the range, below it.
By their numbers in this assay, from the lowest: compound 1; then compound 2; then compound 4. At a limit, above all of these: compound 3.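

In this assay, going by these compounds alone, pyridin-2-yl in place of 4-methoxyphenyl on a saturated ring carbon gives an at least 190-fold lower number from compound 3 to compound 4 (2.28 log units; beyond the scatter), so this position, which no earlier step touched, has a large effect on the read-out. Within the data shown here, the only earlier step, a 7.9-fold higher number from compound 1 to compound 2 (0.90 log units; beyond the scatter), lay on the saturated chain carbon and is printed as modest, while this one is printed as large. Compound 3 gives a limit and not a number, so the new step is a bound and not an exact size: the limit of > 25000 nM in this assay, at which 1 of the 4 values shown sits.

The compounds shown do not separate the arrival of the ring nitrogen of pyridin-2-yl from the loss of the methoxy group, as this one change holds both. As far as these compounds go, it also stays open how a pyrimidine or a fluorophenyl group would read at this place.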